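The compounds below may be only part of what the source reports. "The series", "measured", "known", "first", "only" and "open" are said of these compounds alone.

Measured in a functional assay for inhibition, with Homo sapiens as the target; a lower number here means a stronger inhibitor, a higher number a weaker inhibitor:
- compound 1 `O=C(O)CCCCCCCCCn1nc(-c2ccccc2)c(-c2ccccc2)c1-c1ccccc1`: 5500 nM
- compound 2 `CC(C)(C)OC(=O)COCCCCCCn1nc(-c2ccccc2)c(-c2ccccc2)c1-c1ccccc1`: > 62000 nM (a limit)
- compound 3 `CNC(=O)CCCCCCCCn1nc(-c2ccccc2)c(-c2ccccc2)c1-c1ccccc1`: > 68000 nM (a limit)

Compound 3 has no number in this assay, and its entry is a limit only. The next compound, compound 4 `CS(=O)(=O)NC(=O)CCCCCCCCn1nc(-c2ccccc2)c(-c2ccccc2)c1-c1ccccc1`, carries methylsulfonyl in place of methyl on an amide-type nitrogen.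

Among the compounds with values here, no measured step makes this change itself, so the evidence is indirect. Within the data shown here, two steps start from compound 1, the only compound here with a number and with a free carboxylic acid at the chain end: an at least 11-fold higher number from compound 1 to compound 2 (1.05 log units; beyond the scatter), and an at least 12-fold higher number from compound 1 to compound 3 (1.09 log units; beyond the scatter). The step that the two limits leave unreadable from compound 2 to compound 3 adds nothing. Both large steps show that changing the chain end can shift the reading strongly, and compound 2 and compound 3 both lost the number.

The (methylsulfonyl)carbamoyl end of compound 4 stands where compound 1 has its acid, so a partial return towards compound 1 is expected, with a lower number, though the size is uncertain and a further limit remains possible. The expected change is an at least 5.6-fold lower number from compound 3 to compound 4 (0.75 log units; beyond the scatter). The estimated value for compound 4 is 12000 nM, in a range from 2500 nM to 60000 nM.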

Compound 4, half-maximal inhibitory concentration: 5900 nM
Beside the measured number, compound 4's estimate is 2.0-fold (0.31 log units) above it; the measured number falls inside the stated range.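

In this assay, methylsulfonyl in place of methyl on the amide-type nitrogen gives an at least 11-fold lower number from compound 3 to compound 4 (1.06 log units; beyond the scatter) and restores a readable number; the size is only a bound, as the starting entry is a limit. The same bound applies to the second large step, an at least 10-fold lower number from compound 2 to compound 4 (1.02 log units; beyond the scatter), which also starts from a limit and replaces (tert-butoxycarbonyl)methoxy on the saturated chain carbon. The comparison with the free carboxylic acid end gives a 1.1-fold higher number from compound 1 to compound 4 (0.03 log units; within the scatter), so the (methylsulfonyl)carbamoyl end and the acid end cannot be told apart in this assay, whereas the methylcarbamoyl end has no number; nothing measured here bears on why these ends differ.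

Open, from the compounds shown here alone, is whether other groups on the same nitrogen, such as phenylsulfonyl or trifluoromethylsulfonyl, or a tetrazole at the chain end, would keep a readable number in this assay. Also open, going by these compounds, is whether the match between the (methylsulfonyl)carbamoyl end and the acid end would persist on a shorter or longer chain, or with the phenyl groups of the shared core replaced.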